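The compounds below may be only part of what the source reports. "The series", "measured", "known", "first", "only" and "open" are said of these compounds alone.

Three compounds share one core and differ in a single group. Compound 1 `C[C@@H](Nc1nccc(Cl)c1NC(=O)CC#N)c1ccc(-c2cccc(F)c2C#N)cc1` and compound 2 `C[C@@H](Nc1nccc(Cl)c1NC(=O)CC#N)c1ccc(-c2cccc(F)c2C(F)(F)F)cc1` were run in a functional assay on CHO cells for antagonist activity at B1 bradykinin receptor (Homo sapiens), read by FLIPR and calcium flux (on this read-out higher numbers stand for weaker inhibition and lower numbers for stronger inhibition), without a reported number: compound 1 stands at "not determined" (no result reported) and compound 2 at "not determined" (no result reported). Compound 3 `Cc1noc(-c2c(F)cccc2-c2ccc([C@@H](C)Nc3nccc(Cl)c3NC(=O)CC#N)cc2)n1` carries a result, and in this assay compound 3 gives 0.94 nM. Compound 2 therefore holds no place on the scale, so no size or direction of step from it can be stated. Compound 4 `COC(=O)c1c(Cl)cccc1-c1ccc([C@@H](C)Nc2nccc(Cl)c2NC(=O)CC#N)cc1` arises from compound 2 by one change: 3-chloro-2-(methoxycarbonyl)phenyl in place of 3-fluoro-2-(trifluoromethyl)phenyl on an aromatic carbon. Going by the values given here, the one measured member, compound 3, with 0.94 nM shows how strong this core can be. On that basis compound 4 is expected near 3 nM, within 0.7 nM to 15 nM.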

Compound 4, half-maximal inhibitory concentration: 0.85 nM
Compound 4: middle estimate off by 3.5-fold (0.55 log units), on the high side; the range from low to high includes it.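

Going by these compounds alone, compound 2 has no number on the scale, so no step from it to compound 4 can be read. The compounds shown leave open how far 3-chloro-2-(methoxycarbonyl)phenyl in place of 3-fluoro-2-(trifluoromethyl)phenyl shifts inhibition. No data here offer an explanation for the value of compound 4.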